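Chloro on the naphthalene-type core: expected lipophilicity of compound 4

The source may report more compounds than this note shows. Statements on the series, on what has been measured and on what is new or still open speak of the compounds shown alone.

Measured so far:
compound 1 `COc1c(OC)c(OC(=O)C(C)C)c2ccccc2c1OC(=O)C(C)C` gives 4.61 in a physicochemical assay for lipophilicity; on this read-out lower numbers stand for lower lipophilicity and higher numbers for higher lipophilicity;
compound 2 `COc1c(OC)c(OC(=O)C(C)(C)C)c2ccccc2c1OC(=O)C(C)(C)C` gives 5.69 in this assay;
compound 3 `COc1c(OC)c(OC(=O)C(C)(C)C)c2c(Cl)cccc2c1OC(=O)C(C)(C)C` gives 6.1 in this assay.

Compound 1 has the lowest of the three numbers. How the core of compound 1 differs from that of compound 2 is not broken down here; their values show compound 2 sitting higher. From compound 2 to compound 3 the change is chloro in place of hydrogen on an aromatic carbon, and this step was a number 0.41 log units higher from compound 2 to compound 3 (beyond the scatter).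

Compound 4 `COc1c(OC)c(OC(=O)C(C)C)c2cc(Cl)ccc2c1OC(=O)C(C)C` is not yet measured. It differs from compound 1 by chloro in place of hydrogen on an aromatic carbon. This is the same kind of change as from compound 2 to compound 3, yet the place is not identical: there the chlorine sits ortho to a fused ring and meta to a fused ring, here meta to a fused ring and para to a fused ring. Because a number 0.41 log units higher from compound 2 to compound 3 (beyond the scatter) was a modest rise, a step of similar size is expected for compound 4, namely a number 0.49 log units higher from compound 1 to compound 4 (beyond the scatter). The estimate for compound 4 in this assay is therefore 5.1, expected to fall between 4.7 and 5.5.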

Compound 4, partition coefficient: 5.4
Compound 4: the middle estimate sits 0.30 log units below what was measured; low and high end bracket the measured number.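

In this assay chloro in place of hydrogen on an aromatic carbon gave a number 0.79 log units higher from compound 1 to compound 4 (beyond the scatter) and also a number 0.41 log units higher from compound 2 to compound 3 (beyond the scatter) so the change went the same way on both cores, with both steps modest. Two steps on two cores are still thin support for a rule, and the chlorine sits at a different place in each step, so the influence of the core cannot be separated from that of the place. No evidence shown here gives a reason for either rise.

Chloro at one identical place on both cores remains open. So does whether an amine or a carboxylic acid at the place used in compound 4 would move the number the same way.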